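This account rests on a few compounds, and the source may have more. Where it says the series, first, only, none or still open, it means among the compounds named here.

Compound 1 `CS(=O)(=O)Nc1cccc(-c2nc(C(c3ccc(F)cc3)c3ccc(F)cc3)sc2CC(=O)O)c1` gives 80% in an in vitro functional assay on HEK285-7 cells for antagonist activity at prostaglandin D2 receptor 2 (Homo sapiens), read by BRET and beta-arrestin recruitment; a higher number here means a larger maximal response, a lower number a smaller maximal response. Compound 2 `O=C(O)Cc1sc(C(c2ccc(F)cc2)c2ccc(F)cc2)nc1-c1cccc(F)c1` gives 80%. Compound 3 `Cc1cc(-c2nc(C(c3ccc(F)cc3)c3ccc(F)cc3)sc2CC(=O)O)ccn1` gives 80%.

Compound 3 thus stands level with compounds 1 and 2 in this assay, all three maximal responses falling within the usual scatter of one another. The three steps between them, no change at the digits printed from compound 1 to compound 2 (within the scatter), no change at the digits printed from compound 1 to compound 3 (within the scatter) and no change at the digits printed from compound 2 to compound 3 (within the scatter), each exchanged the aryl group on the shared core without moving the maximal response. Compound 4 `O=C(O)Cc1sc(C(c2ccc(F)cc2)c2ccc(F)cc2)nc1-c1ccnc(O)c1` alters that same group once more: hydroxy in place of methyl on an aromatic carbon, with methyl leaving and hydroxy entering on the six-membered aromatic ring with one nitrogen, next to the ring nitrogen. Because no change at the digits printed from compound 2 to compound 3 (within the scatter) and no change at the digits printed from compound 1 to compound 3 (within the scatter) already left the response unchanged, no step beyond the scatter is expected here: no change at the digits printed from compound 3 to compound 4 (within the scatter). Compound 4 is estimated at 80%, with a range from 65% to 92%.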

Compound 4, largest response reached (reported as efficacy), in percent of the reference or control that the assay uses: 60%
Compound 4: the middle estimate sits 20 percentage points above what was measured, and the stated range ends above it.
By their numbers in this assay, from the lowest: compound 4; then compounds 1, 2 and 3 (each within the scatter of the next).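

In this assay, the carbon next to the ring nitrogen proves sensitive to its substituent: hydroxy in place of methyl gives a number 20 percentage points lower from compound 3 to compound 4 (beyond the scatter). The 2-hydroxypyridin-4-yl group also separates from the other two aryl groups, with a number 20 percentage points lower from compound 2 to compound 4 (beyond the scatter) and a number 20 percentage points lower from compound 1 to compound 4 (beyond the scatter), so this aryl site does not tolerate every exchange, as the first three compounds alone might have suggested. Nothing available explains this drop. Going by these compounds, whether an amine or a methoxy group at this carbon would give a similar drop stays open. So does whether a hydroxy group would have the same effect on the phenyl ring of compound 2.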